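Thiophene for difluorophenyl on the cyclopropane amide

This account rests on a few compounds, and the source may have more. Where it says the series, first, only, none or still open, it means among the compounds named here.

Working notes on the series. In a functional assay for agonist activity at G protein-coupled receptor 88 (Homo sapiens), read by HTRF and cAMP accumulation (on this read-out lower numbers stand for an effect already at smaller amounts and higher numbers for an effect only at larger amounts of compound), compound 1 `CC[C@H](C)[C@H](N)CN(C(=O)[C@@H]1C[C@H]1c1ccc(Cl)cc1)c1ccc(-c2ccccc2)cc1` gives 4300 nM. In this assay compound 2 `CC[C@H](C)[C@H](N)CN(C(=O)[C@@H]1C[C@H]1c1ccc(F)c(F)c1)c1ccc(-c2ccccc2)cc1` gives 720 nM, and compound 3 `CC[C@H](C)[C@H](N)CN(C(=O)[C@@H]1C[C@H]1c1ccc(F)cc1F)c1ccc(-c2ccccc2)cc1` gives 1300 nM. Compound 3 therefore holds the second highest of the three numbers: the step of a 1.8-fold higher number from compound 2 to compound 3 (0.26 log units; within the scatter) stays within the scatter, while the step of a 3.3-fold lower number from compound 1 to compound 3 (0.52 log units; beyond the scatter) lies beyond it.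

Compound 4 `CC[C@H](C)[C@H](N)CN(C(=O)[C@@H]1C[C@H]1c1cccs1)c1ccc(-c2ccccc2)cc1` differs from compound 3 by thiophen-2-yl in place of 2,4-difluorophenyl on a saturated ring carbon. Within the data shown here, the steps that bear on this position are a 6.0-fold lower number from compound 1 to compound 2 (0.78 log units; beyond the scatter), a 3.3-fold lower number from compound 1 to compound 3 (0.52 log units; beyond the scatter) and a 1.8-fold higher number from compound 2 to compound 3 (0.26 log units; within the scatter). Among the measured compounds shown here, each of them exchanges one substituted phenyl for another; no measured step exchanges a phenyl for a five-membered ring with a hetero atom, so the direction of the present change cannot be read from the series. The measured steps at this position are all modest at most, and the expected step of a 1.5-fold higher number from compound 3 to compound 4 (0.19 log units; within the scatter) in this assay is therefore modest as well, with the direction left open. Compound 4 is estimated at 2000 nM in this assay, within a range of 500 nM to 8000 nM.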

Compound 4, half-maximal effective concentration: 360 nM
For compound 4 the middle estimate is 5.6-fold (0.74 log units) above the measured one, and the stated range ends above it.
By their numbers in this assay, from the lowest: compounds 4, 2 and 3 (each within the scatter of the next, the first and the last beyond it); then compound 1.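

Among these compounds, the first exchange of a substituted phenyl for a five-membered ring with a hetero atom holds up at this position in this assay: thiophen-2-yl gives a 3.6-fold lower number from compound 3 to compound 4 (0.56 log units; beyond the scatter) and a 12-fold lower number from compound 1 to compound 4 (1.08 log units; beyond the scatter), the only large step so far. Against 3,4-difluorophenyl the same exchange gives a 2.0-fold lower number from compound 2 to compound 4 (0.30 log units; within the scatter), which stays within the scatter, so compound 4 and compound 2 cannot be told apart here, and a ring without fluorine or chlorine matches the best of the substituted phenyls. No supporting measurement bears on the reason for these steps.

Open, going by these compounds, is whether an unsubstituted phenyl, thiophen-3-yl or furan-2-yl on this carbon would read with compound 4 or with compound 3. Also open, on these data alone, is what a methyl group or a chlorine on the thiophene would do.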